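Methyl in place of thiophen-2-yl: an estimate for compound 4

The source may report more compounds than this note shows. Statements on the series, on what has been measured and on what is new or still open speak of the compounds shown alone.

Measured so far in an assay on Jurkat cells for activation of nuclear factor NF-kappa-B complex (Homo sapiens); a higher number here means a weaker inhibitor, a lower number a stronger inhibitor:
compound 1, `O=C(Nc1cc(C(F)(F)F)cc(C(F)(F)F)c1)c1cnc(-c2ccccc2)nc1`, > 10000 nM (a limit of the assay)
compound 2, `O=C(Nc1cc(C(F)(F)F)cc(C(F)(F)F)c1)c1cnc(Cl)nc1-c1cccs1`, 9800 nM
compound 3, `O=C(Nc1cc(C(F)(F)F)cc(C(F)(F)F)c1)c1cnc(F)nc1C(F)(F)F`, 400 nM

Compound 2 gives 9800 nM in this assay, the highest of the two numbers reported; compound 3 sits far lower at 400 nM, a gap well beyond the scatter. Compound 1 gives only a limit, > 10000 nM, as the one entry that is a limit of the assay (the limit of > 10000 nM in this assay, at which 1 of the 3 values shown sits).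

Compound 4, `Cc1nc(Cl)ncc1C(=O)Nc1cc(C(F)(F)F)cc(C(F)(F)F)c1`, has not yet been measured. It differs from compound 2 in one place: methyl in place of thiophen-2-yl on an aromatic carbon. Among the compounds with values here, no measured pair shows exactly this change, so the expected step rests only on the three values above. Compound 3, which carries trifluoromethyl rather than a ring at the corresponding place, is the strongest compound measured, while compound 2 with its thiophen-2-yl is the weakest number. On that basis compound 4 is expected to land between the two, with the step from compound 2 to compound 4 estimated at a 3.3-fold lower number from compound 2 to compound 4 (0.51 log units; beyond the scatter) toward a lower number. The estimate for compound 4 in this assay is 3000 nM, within a range of 700 nM to 12000 nM.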

Compound 4, half-maximal inhibitory concentration: 50 nM
For compound 4 the middle estimate is 60-fold (1.78 log units) above the measured one; the whole stated range lies above it.
By their numbers in this assay, from the lowest: compound 4; then compound 3; then compound 2. At a limit, above all of these: compound 1.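

With the chloro group and the rest of compound 2 kept, the change of thiophen-2-yl to methyl gives a 200-fold lower number from compound 2 to compound 4 (2.29 log units; beyond the scatter) in this assay. Within the data shown here, this is the first comparison here that isolates one place, and it shows that the aromatic carbon next to the ring nitrogen and ortho to a large group strongly governs the read-out: a single methyl gives a far stronger inhibitor than the five-membered aromatic ring. Nothing measured here explains why this step is so large.

The compounds shown leave open how an amine, a methoxy group or a longer chain such as ethyl at this place would compare with methyl. Among these compounds, they also leave open whether a step of this size would recur with another group in place of chloro, since only one pair shows this change.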